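The compounds below may be only part of what the source reports. "The series", "measured", "known", "first", "only" and "open" are said of these compounds alone.

Compound 1 `COc1ccc(-c2nnc(-c3c[nH]c4ccccc34)o2)cc1OC`: > 1000000 nM
Compound 2 `COc1cc(-c2nnc(-c3c[nH]c4ccccc34)o2)ccc1OCc1ccccc1`: > 1000000 nM

In a functional assay on LNCaP cells (Homo sapiens) for cytotoxicity, read by MTT assay (on this read-out higher numbers stand for weaker inhibition and lower numbers for stronger inhibition), compound 1 gives > 1000000 nM, which is a limit of the assay and not a measured number. Compound 2 gives > 1000000 nM in this assay, again only a limit. Among the measured compounds shown here, the one comparison between measured compounds, a step that the two limits leave unreadable from compound 1 to compound 2, is therefore unreadable in size and direction, since both ends rest on (the limit of > 1000000 nM in this assay, at which 2 of the 2 values shown sit). Compound 3 `COc1cc(-c2nnc(-c3c[nH]c4ccccc34)o2)ccc1O` differs from compound 2 in one place: hydrogen in place of benzyl on an oxygen on an aromatic ring. For the measured compounds named here, no measured step bears on this change, because the single step recorded, a step that the two limits leave unreadable from compound 1 to compound 2, gives no number. With compound 2 standing at a limit, the expectation for compound 3 can only be that it remains near that limit, so the step of a number no higher from compound 2 to compound 3 (the limit leaves the size open) is expected to be small or not measurable. Compound 3 is estimated at 1000000 nM, with a range from 100000 nM to 3000000 nM.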

Compound 3, half-maximal inhibitory concentration: > 1000000 nM
Compound 3 was reported as a limit; the forecaster's own chance of this, stated with the estimate: 80%; the middle value sits exactly at the limit.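

Compound 3 gives > 1000000 nM in this assay, again only a limit and not a measured number. The steps among compound 1, compound 2 and compound 3 therefore cannot be read: the limit of > 1000000 nM in this assay, at which 3 of the 3 values shown sit.

As far as these compounds go, what stays open is whether any change to the shared core would give a measured number in this assay.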